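This account rests on a few compounds, and the source may have more. Where it says the series, first, only, none or still open, it means among the compounds named here.

Compound 1 `O=C1CC2(CO1)CSC(=S)N2c1ccccc1` was examined in a functional assay on PC-3 cells (Homo sapiens) for antiproliferative activity, read by MTT assay, with a stated time of 72 h; on this read-out lower numbers stand for stronger inhibition and higher numbers for weaker inhibition. In this assay compound 1 gives only a limit, > 50 ug/mL. Compound 2 `O=C1CC2(CO1)CSC(=S)N2c1ccc(F)cc1`, carrying fluoro in place of hydrogen on an aromatic carbon, also returns a limit in this assay, > 50 ug/mL. Compound 3 `O=C1CC2(CO1)CSC(=S)N2Cc1ccccc1` likewise returns a limit in this assay, > 50 ug/mL. The step that the two limits leave unreadable from compound 1 to compound 2 therefore cannot be sized, since (the limit of > 50 ug/mL in this assay, at which 3 of the 3 values shown sit). Compound 4 `O=C1CC2(CO1)CSC(=S)N2c1ccccc1O` differs from compound 1 by hydroxy in place of hydrogen on an aromatic carbon. For the measured compounds named here, no measured step bears readably on this change, and the only value of compound 1 is a limit, so the expectation for compound 4 rests on the limit of > 50 ug/mL in this assay, at which 3 of the 3 values shown sit, alone. Compound 4 is expected to give 60 ug/mL, between 30 ug/mL and 120 ug/mL, most likely again as a limit. The expected step is a step that the limit leaves unreadable from compound 1 to compound 4, within the scatter.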

Compound 4, half-maximal inhibitory concentration: > 50 ug/mL
Compound 4 gave a limit, no number; the forecaster's own chance of this, stated with the estimate: 80%; the middle value does not contradict the limit.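

For the compounds shown here, compound 1 and compound 4 both return only limits, so no step between them can be read: the limit of > 50 ug/mL in this assay, at which 4 of the 4 values shown sit. The compounds shown leave open how far any change on the shared core moves the value in this assay.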